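Swapping a methyl for an ethylpiperazine on the benzamide

The compounds below may be only part of what the source reports. "The series", "measured", "known", "first", "only" and "open" are said of these compounds alone.

Measured compounds:
compound 1 `CCc1ccc(C(=O)Nc2ccc(C)c(-n3cc(-c4cccnc4)cn3)c2)cc1` gives 6520 nM
compound 2 `Cc1ccc(NC(=O)c2ccc(C(F)(F)F)cc2)cc1-n1cc(-c2cccnc2)cn1` gives 760 nM

In a functional assay on K562 cells (Homo sapiens) for inhibition, read by MTT assay, with a stated time of 48 h (on this read-out higher numbers stand for weaker inhibition and lower numbers for stronger inhibition), compound 1 stands at the highest of the two numbers shown; its nearest neighbour is compound 2, and an 8.6-fold lower number from compound 1 to compound 2 (0.93 log units; beyond the scatter) separates them. Compound 3 `CCN1CCN(Cc2ccc(C(=O)Nc3ccc(C)c(-n4cc(-c5cccnc5)cn4)c3)cc2)CC1` is the unmeasured partner of compound 1. The change from compound 1 to compound 3 is 4-ethylpiperazin-1-yl in place of methyl on a saturated chain carbon bound to an aromatic carbon. Within the data shown here, the one measured step, from compound 1 to compound 2, alters a different part of the molecule, so it does not speak to this change; no measured pair here varies the group on the saturated chain carbon. With nothing to anchor a direction, the number for compound 3 is expected to stay within the scatter of compound 1, and the step of a 1.6-fold lower number from compound 1 to compound 3 (0.21 log units; within the scatter) is therefore an estimate with a wide range. Compound 3 is estimated at 4000 nM, between 800 nM and 20000 nM.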

Compound 3, half-maximal inhibitory concentration: 2330 nM
Compound 3: the middle estimate sits 1.7-fold (0.23 log units) above what was measured; the range from low to high includes it.
By their numbers in this assay, from the lowest: compound 2; then compound 3; then compound 1.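

Among these compounds, putting 4-ethylpiperazin-1-yl in place of methyl on a saturated chain carbon bound to an aromatic carbon is the first change at this place, and in this assay it gives a 2.8-fold lower number from compound 1 to compound 3 (0.45 log units; beyond the scatter) and thus stronger inhibition, so this place accepts a much larger group that brings in a ring. That gain does not reach what trifluoromethyl achieves, as swapping that group for (4-ethylpiperazin-1-yl)methyl gives a 3.1-fold higher number from compound 2 to compound 3 (0.49 log units; beyond the scatter) and thus weaker inhibition. Nothing available explains either step.

As far as these compounds go, it remains open whether the ring or its ethyl matters here, which a morpholine or a simple dimethylamino group at the same place could help to show. From the compounds shown here alone, it is also open how a compound carrying both trifluoromethyl and (4-ethylpiperazin-1-yl)methyl would behave.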